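Swapping an aryl group for cyclopropyl on a shared core

This account rests on a few compounds, and the source may have more. Where it says the series, first, only, none or still open, it means among the compounds named here.

Measured so far:
Compound 1 `Cn1ncc2c(-c3ccccc3)cc(NNC(=O)Nc3cc(Cl)nc(Cl)c3)nc21` gives 76900 nM in a functional assay on SW620/5-FU cells (Homo sapiens) for cytotoxicity, read by MTT assay, with a stated time of 48 h, in the presence of a further agent that is not named here; a higher number here means that more compound is needed for the effect, a lower number that less compound is needed.
Compound 2 `Cc1nn(C)c2nc(NNC(=O)Nc3cc(Cl)nc(Cl)c3)cc(-c3ccc(F)cc3)c12` gives 17400 nM in this assay.

Of these two numbers, compound 2 holds the lower one, and its gap to compound 1 lies beyond the usual scatter. Compound 3 `Cc1nn(C)c2nc(NNC(=O)Nc3cc(Cl)nc(Cl)c3)cc(C3CC3)c12` has not been measured; it differs from compound 2 by cyclopropyl in place of 4-fluorophenyl on an aromatic carbon. Within the data shown here, no measured pair shows this kind of change, so there is no step to lean on. The step from compound 2 to compound 3 is expected to be a 1.7-fold higher number from compound 2 to compound 3 (0.24 log units; within the scatter), a mild rise. Compound 3 is therefore estimated at 30000 nM, within a range from 8000 nM to 120000 nM.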

Compound 3, half-maximal effective concentration: 80800 nM
Estimate against measurement, compound 3: 2.7-fold (0.43 log units) below, and the stated range covers the measured number.
By their numbers in this assay, from the lowest: compound 2; then compounds 1 and 3 (each within the scatter of the next).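

In this assay, the swap of 4-fluorophenyl for cyclopropyl on this aromatic carbon gives a 4.6-fold higher number from compound 2 to compound 3 (0.67 log units; beyond the scatter). This position therefore responds to the group it carries, and here the 4-fluorophenyl compound needs less compound for the effect. Nothing measured here explains why the number moves.

As far as these compounds go, it remains open whether the aromatic ring or its fluorine accounts for the difference, which a plain phenyl on this same core could help separate. How an amine or a longer alkyl chain would behave at this position is also unknown.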